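The compounds below may be only part of what the source reports. "The series", "measured", "known", "first", "only" and "open" are said of these compounds alone.

The compounds here share one core and differ only in the group attached at a saturated chain carbon bound to an oxygen on an aromatic ring. Compound 3 `CCN(CC)C(=O)COc1ccc(C[C@H]2C(=O)OC[C@@H]2Cc2ccc(OC)c(OC)c2)cc1OC` carries a diethylcarbamoyl group there, and in an ADME assay on HeLa cells (Homo sapiens) for cytotoxicity, read by MTT assay (a lower number here means a stronger inhibitor, a higher number a weaker inhibitor), compound 3 gives 188000 nM. Among the numbers measured, compound 3 stands highest of two, though its nearest neighbour, compound 1 `COc1ccc(C[C@H]2COC(=O)[C@@H]2Cc2ccc(OCc3cn(-c4ccc(Br)cc4)nn3)c(OC)c2)cc1OC`, sits within the scatter of it: in this assay compound 1 gives 128000 nM. Compound 2 `COc1ccc(C[C@H]2COC(=O)[C@@H]2Cc2ccc(OCc3cn(-c4ccc(C)cc4)nn3)c(OC)c2)cc1OC` reached only a limit of the assay, >= 600000 nM in this assay, and not a number (the limit of >= 600000 nM in this assay, at which 1 of the 3 values shown sits).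

Compound 4 `COc1ccc(C[C@H]2COC(=O)[C@@H]2Cc2ccc(OCc3cn(-c4ccc(Cl)cc4)nn3)c(OC)c2)cc1OC` is the unmeasured compound; its change from compound 3 is 1-(4-chlorophenyl)-1H-1,2,3-triazol-4-yl in place of diethylcarbamoyl on a saturated chain carbon bound to an oxygen on an aromatic ring. For the measured compounds named here, the step that bears most on this runs the opposite way, a 1.5-fold higher number from compound 1 to compound 3 (0.17 log units; within the scatter), and the group entering compound 4 differs from the one that left compound 1 only in chloro in place of bromo. The other two steps, an at least 4.6-fold higher number from compound 1 to compound 2 (0.67 log units; beyond the scatter) and an at least 3.1-fold lower number from compound 2 to compound 3 (0.50 log units; beyond the scatter), concern the methyl variant and end at a limit. For compound 4 the expected step is therefore a 1.7-fold lower number from compound 3 to compound 4 (0.23 log units; within the scatter), small and within the scatter. Compound 4 is estimated at 110000 nM, within 50000 nM to 260000 nM.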

Compound 4, half-maximal inhibitory concentration: 279000 nM
Estimate against measurement, compound 4: 2.5-fold (0.40 log units) below; the whole stated range lies below it.
By their numbers in this assay, from the lowest: compounds 1, 3 and 4 (each within the scatter of the next, the first and the last beyond it). At a limit, above all of these: compound 2.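

In this assay, replacing the whole group on the saturated chain carbon gives a 1.5-fold higher number from compound 3 to compound 4 (0.17 log units; within the scatter), so 1-(4-chlorophenyl)-1H-1,2,3-triazol-4-yl and diethylcarbamoyl cannot be told apart at this position, despite their different size and rings. The smaller exchange of bromo for chloro on an aromatic carbon gives a 2.2-fold higher number from compound 1 to compound 4 (0.34 log units; beyond the scatter), which lies beyond the scatter, so within the triazole series the number responds to a single atom, even though the whole-group exchange in compound 4 does not register. The exchange of chloro in place of methyl gives an at least 2.1-fold lower number from compound 2 to compound 4 (0.33 log units; beyond the scatter), also beyond the scatter, but its true size is unknown, as compound 2 stands at a limit of the assay and not at a number: the limit of >= 600000 nM in this assay, at which 1 of the 4 values shown sits.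

From the compounds shown here alone, only bromo, chloro and methyl appear on that aromatic carbon, so it remains open where fluoro, methoxy or a plain hydrogen there would fall. At the saturated chain carbon itself, only diethylcarbamoyl and the substituted phenyl triazoles are shown, which leaves open what a carboxylic acid or a simple amine in that place would give.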